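Methyl to fluoro on compound 2

The compounds below may be only part of what the source reports. "The series", "measured", "known", "first", "only" and "open" are said of these compounds alone.

Compound 1 `CCOC(=O)c1cnc2ccc(-c3ccccc3)cc2c1` gives > 7400 nM (a limit)
Compound 2 `Cc1ccc(-c2ccc3ncc(-c4noc(C(F)(F)F)n4)cc3c2)cc1` gives > 22200 nM (a limit)

Both compounds were tested in a functional assay on RD cells (Homo sapiens) for inhibition, read by luminescence and ATP content, with a stated time of 72 h (on this read-out higher numbers stand for lower toxicity in this test and lower numbers for higher toxicity in this test), and neither returned an exact number. Compound 2 stands at a limit (> 22200 nM). Compound 1 also stands at a limit, so the two cannot be ranked against each other.

The next compound, compound 3 `Fc1ccc(-c2ccc3ncc(-c4noc(C(F)(F)F)n4)cc3c2)cc1`, has not yet been measured. It differs from compound 2 in one place (fluoro in place of methyl on an aromatic carbon), with fluoro in place of methyl on an aromatic carbon, para to a large group. In other words, 4-methylphenyl becomes 4-fluorophenyl.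

Among the measured compounds shown here, no measured pair shows what a change like this does here, so the only anchor is compound 2 (> 22200 nM). The expected step of a number no higher from compound 2 to compound 3 (the limit leaves the size open) in this assay is none beyond the usual scatter, in either direction. Compound 3 may well return only a limit too. If a number does appear, compound 3 is estimated at 22200 nM, with an expected range from 9000 nM to 50000 nM.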

Compound 3, half-maximal cytotoxic concentration: > 7400 nM
Compound 3 gave a limit, no number; the forecaster's own chance of this, stated with the estimate: 75%; the middle value lies beyond the limit too.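

In this assay compound 3 gives > 7400 nM, which is a limit and not a number. Compound 2 also gives only a limit, so no step can be read between compound 2 and compound 3. The compounds shown leave open whether 4-methylphenyl and 4-fluorophenyl differ at all in this assay.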